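Swapping Methyl for Trifluoromethyl on a Chk2 Inhibitor

The compounds below may be only part of what the source reports. "The series", "measured", "known", "first", "only" and "open" are said of these compounds alone.

Of the compounds shown here, two sharing a common core have been measured in an assay on isolated protein for inhibition of serine/threonine-protein kinase Chk2 (Homo sapiens); on this read-out higher numbers stand for weaker inhibition and lower numbers for stronger inhibition. Compound 1, `Cc1ccc(O)c(-c2nc(N[C@H]3CCNC3)c3ccccc3n2)c1`, gives 92 nM in this assay. Compound 2, `OC[C@H]1C[C@H](Nc2nc(-c3cc(F)ccc3O)nc3ccccc23)CN1`, gives 81 nM in this assay. Of these two numbers, compound 1 has the higher one, but its gap to compound 2 lies within the usual scatter, so the two compounds are best read as equivalent on this read-out.

Compound 3, `Oc1ccc(C(F)(F)F)cc1-c1nc(N[C@H]2CCNC2)c2ccccc2n1`, has not been measured yet. It differs from compound 1 in one place: trifluoromethyl in place of methyl on an aromatic carbon. The incoming group adds no hydrogen-bond donor or acceptor and carries no net charge, so the count of polar features on the core is unchanged.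

Among the measured compounds shown here, no measured pair shows what such an exchange does here, so an expectation can rest only on the narrow spread between compound 1 and compound 2 and on the small extent of the edit. Compound 3 is therefore expected to stay near compound 1, with the expected step of a 1.1-fold higher number from compound 1 to compound 3 (0.04 log units; within the scatter) reaching no further than the scatter in either direction. The estimate for compound 3 is 100 nM, within a range from 40 nM to 250 nM.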

Compound 3, half-maximal inhibitory concentration: 201 nM
Compound 3: middle estimate off by 2.0-fold (0.30 log units), on the low side; measured number inside the range.
By their numbers in this assay, from the lowest: compounds 2 and 1 (each within the scatter of the next); then compound 3.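

This position is not indifferent to what sits on it. On this aromatic carbon, para to a hydroxy group and meta to a large group, trifluoromethyl in place of methyl gives a 2.2-fold higher number from compound 1 to compound 3 (0.34 log units; beyond the scatter) in this assay and so moves the compound towards weaker inhibition, a modest change but the first one here that clears the usual scatter of repeated measurements. No measurement on these compounds bears on why this exchange weakens inhibition, so the result records the size and direction of the step and no explanation for it.

Going by these compounds, what remains open is how other groups behave on the same carbon: a bare hydrogen, a chlorine atom, a methoxy group or a nitrile could each be compared with methyl to show whether trifluoromethyl is an isolated penalty or part of a wider trend. On these data alone, it is also open whether the same exchange costs as much on a different amine part of the molecule, such as the hydroxymethyl-bearing ring of compound 2, since one step on one core cannot show whether the effect carries over.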